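The source may hold more compounds than are shown below. What is called first, only, known or untested is meant among the compounds shown, and "the series" means these compounds.

Compound 1 `COC(=O)/C=C/c1cccc(N(Cc2ccc(/C=C/c3c(Cl)cccc3Cl)cc2)C(=O)C(C)C)c1` was tested in an assay on isolated protein with Bile acid receptor (Homo sapiens) as the target (on this read-out higher numbers stand for an effect only at larger amounts of compound and lower numbers for an effect already at smaller amounts), where compound 1 gives 195 nM. Among the three measured numbers this is the second highest; compound 2 `COC(=O)/C=C/c1cccc(N(Cc2ccc(/C=C/C(=O)OC(C)(C)C)cc2)C(=O)NC(C)C)c1` gives 212 nM and compound 3 `COC(=O)/C=C/c1cccc(N(Cc2ccc(/C=C/c3c(Cl)cccc3Cl)cc2)C(=O)C2CCCCC2)c1` gives 150 nM, both within the scatter of compound 1. Within the data shown here, the only single-place step measured, a 1.3-fold lower number from compound 1 to compound 3 (0.11 log units; within the scatter), concerns the group on the carbonyl carbon and not the part altered here. Compound 4 `COC(=O)/C=C/c1cccc(N(Cc2ccc(/C=C/c3cccc(Cl)c3)cc2)C(=O)C(C)C)c1` differs from compound 1 by 3-chlorophenyl in place of 2,6-dichlorophenyl on a double-bonded chain carbon bound to a double-bonded chain carbon. Among the measured compounds shown here, no measured step bears on this change, so the record offers no direct guide to its size or direction. Resting mainly on compound 1 and its 195 nM, and allowing for a somewhat higher number, compound 4 is expected at 400 nM, with a range of 150 nM to 1100 nM, an expected step of a 2.1-fold higher number from compound 1 to compound 4 (0.31 log units; beyond the scatter).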

Compound 4, half-maximal effective concentration: 164 nM
For compound 4 the middle estimate is 2.4-fold (0.39 log units) above the measured one, and the stated range covers the measured number.
By their numbers in this assay, from the lowest: compounds 3, 4, 1 and 2 (each within the scatter of the next).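

Replacing 2,6-dichlorophenyl with 3-chlorophenyl on a double-bonded chain carbon bound to a double-bonded chain carbon gives a step within the scatter (a 1.2-fold lower number from compound 1 to compound 4 (0.08 log units; within the scatter)). At this position, then, the number does not depend on keeping the 2,6-dichloro pattern, and one chlorine fewer leaves it within the scatter. Nothing in hand gives a reason for this result.

The compounds shown leave open whether chlorine is needed at all at this position. An unsubstituted phenyl, or a phenyl carrying a methoxy group or an amine, could answer that.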